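Methylation of the ring amide nitrogen in two related series

A few compounds are considered here, and "the series" means these few. Any claim that something is new, unique, unknown or untested is made for them only; others in the source may bear on it.

Compound 1 `COc1cc2c(cc1C)NC(=O)/C2=C/c1c(Cl)n(C)c2cc(C)c(OC)cc12` and compound 2 `COc1cc2c(cc1C)N(C)C(=O)/C2=C/c1c(Cl)n(C)c2cc(C)c(OC)cc12` share one core. In a functional assay on cells (Melanoma cell, Homo sapiens) for inhibition, with a stated time of 48 h (a higher number here means a weaker inhibitor of growth, a lower number a stronger inhibitor of growth), compound 1 gives 45700 nM, and compound 2 gives 67600 nM. The change between them is methyl in place of hydrogen on an amide-type nitrogen in a ring, and that step made a 1.5-fold higher number from compound 1 to compound 2 (0.17 log units; within the scatter). Compound 3 `CN(C)c1ccc2[nH]c(Cl)c(/C=C3/C(=O)Nc4ccc(O)cc43)c2c1` stands on a different core; the difference between the two cores is not broken down here. In this assay compound 3 gives 25700 nM. Compound 4 `CN(C)c1ccc2[nH]c(Cl)c(/C=C3/C(=O)N(C)c4ccc(O)cc43)c2c1` has not yet been measured; it differs from compound 3 by methyl in place of hydrogen on an amide-type nitrogen in a ring, the same change that turned compound 1 into compound 2. Within the data shown here, that earlier step, a 1.5-fold higher number from compound 1 to compound 2 (0.17 log units; within the scatter), is the only guide available. On that basis compound 4 is expected to follow with a 1.5-fold higher number from compound 3 to compound 4 (0.17 log units; within the scatter). Compound 4 is therefore estimated at 38000 nM, with a likely range from 15000 nM to 100000 nM.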

Compound 4, concentration for total growth inhibition: 26300 nM
Beside the measured number, compound 4's estimate is 1.4-fold (0.16 log units) above it; the range from low to high includes it.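

In this assay, methyl in place of hydrogen on the amide-type nitrogen in a ring gave a 1.0-fold higher number from compound 3 to compound 4 (0.01 log units; within the scatter). Set beside the earlier step, the same change reads alike on the two cores: the same change on two cores in this assay, a 1.5-fold higher number (0.17 log units; within the scatter) from compound 1 to compound 2 and a 1.0-fold higher number (0.01 log units; within the scatter) from compound 3 to compound 4, 1.4-fold (0.16 log units) apart, within the scatter of two such steps. This shows that the step carried over from one core to the other with both results inside the scatter, but it rests on just two pairs and does not show that the change would behave this way on any further core.

The compounds shown leave open whether a longer chain, such as ethyl, or a chain ending in an amine or a carboxylic acid, would behave like methyl on this nitrogen. They also leave open whether the same holds for other read-outs or other cell types.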